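A chloro-substituted pair and its expected growth inhibition

This account rests on a few compounds, and the source may have more. Where it says the series, first, only, none or still open, it means among the compounds named here.

In a functional assay on SW982 cells (Homo sapiens) for inhibition, read by MTT assay, with a stated time of 72 h (on this read-out higher numbers stand for weaker inhibition and lower numbers for stronger inhibition), compound 1 `COc1cc(OC)c(OC)cc1/C=C/C(=O)c1cc(OC(C)=O)ccc1OC(C)=O` gives 78500 nM and compound 3 `COc1cc(OC)c(C(=O)/C=C/c2cc(OC)c(OC)cc2OC)c(OC)c1` gives 96500 nM. Compound 2 `COc1cc(OC)c(OC)cc1/C=C/C(=O)c1cc(Cl)ccc1O` stands apart: it returns only a limit of the assay, > 150000 nM, and no number, as recorded by the limit of > 150000 nM in this assay, at which 1 of the 3 values shown sits. Compound 4 `COc1cc(OC)c(OC)cc1/C=C/C(=O)c1ccc(Cl)cc1` has not yet been measured in this assay. It differs from compound 2 in one place: 4-chlorophenyl in place of 5-chloro-2-hydroxyphenyl on a carbonyl carbon. Within the data shown here, no measured pair in the set shares this change, so the size and direction of the step rest on no measured precedent. Compound 4 is expected to fall near 110000 nM in this assay, between 35000 nM and 300000 nM. The expected step is an at least 1.3-fold lower number from compound 2 to compound 4 (0.13 log units; that floor lies within the scatter), which is judged not beyond the scatter, with a fair chance that only a limit is reported again.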

Compound 4, half-maximal inhibitory concentration: 58500 nM
Compound 4: the middle estimate sits 1.9-fold (0.27 log units) above what was measured, within the range that was stated.
By their numbers in this assay, from the lowest: compounds 4, 1 and 3 (each within the scatter of the next). At a limit, above all of these: compound 2.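

Setting 4-chlorophenyl in place of 5-chloro-2-hydroxyphenyl on a carbonyl carbon gives, in this assay, an at least 2.5-fold lower number from compound 2 to compound 4 (0.40 log units; beyond the scatter), the first step measured at this place. The ring on the carbonyl carbon therefore bears on the read-out, and the change gives a measurable number where only a limit stood before. That step is only a floor because compound 2 stands at a limit of the assay: the limit of > 150000 nM in this assay, at which 1 of the 4 values shown sits.

The pair changes the chlorine's place and the hydroxy group together, so their shares remain unseparated. Going by these compounds, how an amine or a carboxylic acid on this ring would read remains open.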